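The compounds below may be only part of what the source reports. "The series", "measured", "known", "first", "only" and "open" are said of these compounds alone.

Among the compounds with values here, compound 3 `O=C(COc1ccc(/C=C2\SC(=O)NC2=O)cc1)Nc1ccc(Cl)cc1` is the only member of this small series with a numeric result: in a functional assay on PC-3 cells (Homo sapiens) for inhibition (a higher number here means a weaker inhibitor of growth, a lower number a stronger inhibitor of growth), compound 3 gives 83400 nM. Compound 1 `Cc1cccc2sc(NC(=O)COc3ccc(/C=C4\SC(=O)NC4=O)cc3)nc12` reaches only the limit of the assay, giving > 100000 nM in this assay. Compound 2 `O=C(COc1ccc(/C=C2\SC(=O)NC2=O)cc1)Nc1ccccc1` likewise stops at the limit, with > 100000 nM in this assay. Within the data shown here, the one measured step, an at least 1.1-fold lower number from compound 2 to compound 3 (0.07 log units; that floor lies within the scatter), is a chloro in place of hydrogen on an aromatic carbon; since (the limit of > 100000 nM in this assay, at which 2 of the 3 values shown sit), its true size stays open. Compound 4 `Cc1ccc(NC(=O)COc2ccc(/C=C3\SC(=O)NC3=O)cc2)cc1Cl` differs from compound 3 by 3-chloro-4-methylphenyl in place of 4-chlorophenyl on an amide-type nitrogen. Among the measured compounds shown here, the measured step bears on it only loosely: the chloro substituent is retained and a methyl enters on the same ring, a change for which no step has been measured. No step beyond the scatter is expected in this assay; the step of a 1.0-fold lower number from compound 3 to compound 4 (0.02 log units; within the scatter) is therefore expected to be small. The estimate for compound 4 is 80000 nM, within 30000 nM to 150000 nM, with a real chance that compound 4 reports only the limit.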

Compound 4, concentration for 50% growth inhibition: > 100000 nM
Compound 4 ended at the assay's limit (the forecaster's own chance of this, stated with the estimate: 40%); at least 1.2-fold (0.09 log units) between middle value and limit.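

In this assay, 3-chloro-4-methylphenyl in place of 4-chlorophenyl on an amide-type nitrogen gives an at least 1.1-fold higher number from compound 3 to compound 4 (0.07 log units; that floor lies within the scatter), so this position has now been varied without any numeric gain over compound 3. Compound 4 gives > 100000 nM, which is a limit of the assay. Compound 3 remains the only member with a numeric result, and the step from compound 2 to compound 4 and the true size of the step to compound 4 cannot be read because the values sit at the limit: the limit of > 100000 nM in this assay, at which 3 of the 4 values shown sit.

Going by these compounds, whether any substituent at this position can bring the series to a clearly readable potency remains open. An amine or a carboxylic acid on the aromatic ring in place of the chloro, or a longer chain in place of the methyl, would test this.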